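Chloromethyl in Place of Oxopropoxy: Expecting Compound 3

The source may hold more compounds than are shown below. What is called first, only, known or untested is meant among the compounds shown, and "the series" means these compounds.

Compound 1 `COc1cc(=O)oc2cc(OCc3cccc(F)c3)ccc12`: 49%
Compound 2 `CC(=O)COc1cc(=O)oc2cc(OCc3cccc(Cl)c3)ccc12`: 22%

In an assay on isolated protein (strain Sprague-Dawley) for inhibition of Amine oxidase [flavin-containing] A (Rattus norvegicus), read by spectrophotometry, with a stated time of 5 min, tested at 10 uM (on this read-out lower numbers stand for less inhibition and higher numbers for more inhibition at the one concentration tested (going by the name of the read-out)), compound 2 gives 22%, the lowest of the two numbers; compound 1 gives 49%, a gap beyond the usual scatter. Compound 3 `O=c1cc(CCl)c2ccc(OCc3cccc(Cl)c3)cc2o1` differs from compound 2 by chloromethyl in place of 2-oxopropoxy on an aromatic carbon. Among the measured compounds shown here, no measured pair shows a change of this kind, so its direction is open. A modest rise is expected, with a step of a number 13 percentage points higher from compound 2 to compound 3 (beyond the scatter) that would only just clear the scatter. Compound 3 is therefore estimated at 35%, with a range from 10% to 65%.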

Compound 3, a percentage reported as inhibition, at one concentration (the size of the read-out at that concentration, not a potency): 21%
Compound 3: the middle estimate sits 14 percentage points above what was measured; the measured number falls inside the stated range.
By their numbers in this assay, from the lowest: compounds 3 and 2 (each within the scatter of the next); then compound 1.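

At this position, opposite the ring oxygen, chloromethyl in place of 2-oxopropoxy gives, in this assay, a number 1 percentage points lower from compound 2 to compound 3 (within the scatter), so compound 2 and compound 3 read alike. The 5 heavy atoms and 2 hydrogen-bond acceptors of 2-oxopropoxy give way to the 2 heavy atoms and no acceptors of chloromethyl without a step beyond the scatter. No evidence at hand explains this result. Going by these compounds, whether an amine, a carboxylic acid or a longer chain on this carbon would give a different number remains open.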